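A few compounds are considered here, and "the series" means these few. Any claim that something is new, unique, unknown or untested is made for them only; others in the source may bear on it.

The measured compounds and their values in a functional assay on the whole organism (artery, strain albino) with Rattus norvegicus as the target, with a stated time of 120 min, at a dose of 10 mg/kg by the oral route; on this read-out higher numbers stand for more inhibition at the one dose given (going by the name of the read-out) and lower numbers for less inhibition:
compound 1, `COc1ccc(C2N=C(SCc3ccc(Cl)cc3)NC(C)=C2C(=O)Nc2ccc(F)cc2)cc1OC`, 15.5%
compound 2, `COc1ccc(C2N=C(SCc3ccc(F)cc3)NC(C)=C2C(=O)Nc2ccc(F)cc2)cc1OC`, 15.5%
compound 3, `CC1=C(C(=O)Nc2ccc(F)cc2)C(c2ccc([N+](=O)[O-])cc2)N=C(SCc2ccc(Cl)cc2)N1`, 16%

Compound 1 and compound 2 differ by a single change, (fluoro in place of chloro on an aromatic carbon), and that change gave no change at the digits printed from compound 1 to compound 2 (within the scatter). The same change separates compound 3 from the unmeasured compound 4, `CC1=C(C(=O)Nc2ccc(F)cc2)C(c2ccc([N+](=O)[O-])cc2)N=C(SCc2ccc(F)cc2)N1`: fluoro in place of chloro on an aromatic carbon. The place of the change is described in the same words for both pairs, so it is the same change carried out on a different core. The two cores differ by 4-nitrophenyl in place of 3,4-dimethoxyphenyl on a saturated ring carbon, a difference that on its own gave a number 0.5 percentage points higher from compound 1 to compound 3 (within the scatter). All three measured numbers lie within the usual scatter of one another, so no ordering among compound 1, compound 2 and compound 3 can be drawn from them. Among the measured compounds shown here, since the earlier step was flat and the core change was flat as well, the step from compound 3 to compound 4 is expected to be no change at the digits printed from compound 3 to compound 4 (within the scatter) in this assay, resting on the first pair because no change at the digits printed from compound 1 to compound 2 (within the scatter). Compound 4 is therefore estimated to give 16% in this assay, with a likely range from 8% to 25%.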

Compound 4, a percentage reported as inhibition, in the whole organism at one dose (the size of the read-out at that dose, not a potency): 17%
The estimate for compound 4 lay 1 percentage points below the measured number, and the stated range covers the measured number.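

In this assay, fluoro in place of chloro on an aromatic carbon gave a number 1 percentage points higher from compound 3 to compound 4 (within the scatter), and set beside the same change on the core of compound 1, the two steps agree: the same change on two cores in this assay, no change at the digits printed (within the scatter) from compound 1 to compound 2 and a number 1 percentage points higher (within the scatter) from compound 3 to compound 4, 1 percentage points apart, within the scatter of two such steps The change of core, 4-nitrophenyl in place of 3,4-dimethoxyphenyl on a saturated ring carbon, gave a number 1.5 percentage points higher from compound 2 to compound 4 (within the scatter), and it too reads alike with chloro and with fluoro: the same change on two cores in this assay, a number 0.5 percentage points higher (within the scatter) from compound 1 to compound 3 and a number 1.5 percentage points higher (within the scatter) from compound 2 to compound 4, 1 percentage points apart, within the scatter of two such steps This shows that both changes stayed flat across the compounds shown at the one dose given, but it does not show that a change with a step beyond the scatter would carry from one core to another, since every step here lies within the scatter.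

The compounds shown leave open whether an amine or a carboxylic acid in place of the halogen on that aromatic carbon would move the number in this assay. They also leave open whether a longer chain in place of the 4-fluorobenzyl would do so, and whether any such step would hold on both cores.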